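A few compounds are considered here, and "the series" means these few. Any claim that something is new, unique, unknown or untested is made for them only; others in the source may bear on it.

Measured compounds:
compound 1 `CCOc1cc(NC(=O)C2(NC(=O)c3ccc4c(C5CCCC5)c(-c5ncc(Cl)cn5)n(C)c4c3)CCC2)ccc1/C=C/C(=O)OC(=O)C[C@H](O)C(=O)O`, 7.92 h
compound 2 `CCOc1cc(NC(=O)C2(NC(=O)c3ccc4c(C5CCCC5)c(-c5ncc(Cl)cn5)n(C)c4c3)CCC2)ccc1/C=C/C(=O)OCOP(=O)(O)OC(C)(C)C`, 0.133 h
compound 3 `CCOc1cc(NC(=O)C2(NC(=O)c3ccc4c(C5CCCC5)c(-c5ncc(Cl)cn5)n(C)c4c3)CCC2)ccc1/C=C/C(=O)OCC(Cl)(Cl)Cl`, 0.233 h

Compound 3 stands second highest of the three numbers in an ADME assay (liver) for pharmacokinetics, with Liver microsome (Rattus norvegicus) as the target, using microsomes; a higher number here means that the compound lasts longer, a lower number that the compound disappears faster: its nearest neighbour is compound 2, at a 1.8-fold higher number from compound 2 to compound 3 (0.24 log units; within the scatter), and its furthest is compound 1, from which it is separated by a 34-fold lower number from compound 1 to compound 3 (1.53 log units; beyond the scatter). Compound 4 `CCOc1cc(NC(=O)C2(NC(=O)c3ccc4c(C5CCCC5)c(-c5ncc(Cl)cn5)n(C)c4c3)CCC2)ccc1/C=C/C(=O)OCCOc1ccccc1` is not yet measured in this assay. It differs from compound 3 by phenoxymethyl in place of trichloromethyl on a saturated chain carbon bound to an oxygen next to a carbonyl group.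

Among the measured compounds shown here, the one measured step at the same place, the saturated chain carbon bound to an oxygen next to a carbonyl group, is a 1.8-fold higher number from compound 2 to compound 3 (0.24 log units; within the scatter), which stayed within the scatter. The two large steps, a 60-fold lower number from compound 1 to compound 2 (1.77 log units; beyond the scatter) and a 34-fold lower number from compound 1 to compound 3 (1.53 log units; beyond the scatter), both start from compound 1 and replace the (2-carboxy-2-hydroxyethyl)carbonyl group, so they do not speak directly to a change made on the ethyl carbon. On this basis compound 4 is expected to sit close to compound 3 and compound 2, with a step of a 1.3-fold higher number from compound 3 to compound 4 (0.11 log units; within the scatter) that is not expected to pass beyond the scatter. The estimate for compound 4 in this assay is 0.3 h, with a range from 0.08 h to 1.2 h.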

Compound 4, half-life: 16.5 h
The estimate for compound 4 lay 55-fold (1.74 log units) below the measured number, outside the stated range (above it).
By their numbers in this assay, from the lowest: compounds 2 and 3 (each within the scatter of the next); then compound 1; then compound 4.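

In this assay the saturated chain carbon bound to an oxygen next to a carbonyl group proves sensitive to the group it carries: phenoxymethyl in place of trichloromethyl gives a 71-fold higher number from compound 3 to compound 4 (1.85 log units; beyond the scatter) whereas the earlier step of a 1.8-fold higher number from compound 2 to compound 3 (0.24 log units; within the scatter) showed nothing of the kind. The step of a 120-fold higher number from compound 2 to compound 4 (2.09 log units; beyond the scatter) at the same place points the same way. Measured against compound 1, 2-phenoxyethyl in place of (2-carboxy-2-hydroxyethyl)carbonyl gives a 2.1-fold higher number from compound 1 to compound 4 (0.32 log units; beyond the scatter) and so shows that a long half-life in this set does not depend on that group.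

Going by these compounds, whether the gain belongs to the aromatic ring, the chain oxygen or both stays open, as does how a 2-aminoethyl group or a longer chain ending in phenoxy would read in this assay at this place. Nothing available bears on what lies behind these steps.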